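Dropping the Ethyl Group on a Shared Core

The source may report more compounds than this note shows. Statements on the series, on what has been measured and on what is new or still open speak of the compounds shown alone.

Compound 1 `CCC1(CCCCN2CCN(c3ccc(Cl)cc3)CC2)C(=O)Nc2cc(F)ccc21` — 215 nM
Compound 2 `CCC1(CCCCN2CCN(c3ccc(Cl)cc3)CC2)C(=O)Nc2ccccc21` — 93 nM

In an assay on membranes from frontal cortex for displacement of a labelled ligand from Adrenergic receptor alpha-1 (Rattus norvegicus), read by scintillation counting, with a stated time of 45 min (on this read-out higher numbers stand for weaker inhibition and lower numbers for stronger inhibition), compound 1 gives 215 nM, the highest of the two numbers recorded. Going by the values given here, its only neighbour is compound 2, which gives 93 nM; the step between them, a 2.3-fold lower number from compound 1 to compound 2 (0.36 log units; beyond the scatter), is a change of hydrogen in place of fluoro on an aromatic carbon.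

Compound 3 `O=C1Nc2cc(F)ccc2C1CCCCN1CCN(c2ccc(Cl)cc2)CC1` differs from compound 1 in another way: hydrogen in place of ethyl on a saturated ring carbon. Among the compounds with values here, neither measured step touches this saturated ring carbon; the single step known concerns the fluoro on the aromatic ring and does not bear on the present change. The expectation for compound 3 therefore rests on compound 1 alone, with wide uncertainty and no clear direction. Compound 3 is expected to give about 250 nM, within a range of 80 nM to 800 nM. This estimate amounts to an expected 1.2-fold higher number from compound 1 to compound 3 (0.07 log units; within the scatter).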

Compound 3, inhibition constant: 55 nM
Estimate against measurement, compound 3: 4.5-fold (0.66 log units) above; measured number below the stated range.
By their numbers in this assay, from the lowest: compounds 3 and 2 (each within the scatter of the next); then compound 1.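

In this assay the step at the saturated ring carbon, two ring bonds from the ring nitrogen, is a 3.9-fold lower number from compound 1 to compound 3 (0.59 log units; beyond the scatter) and shows that this position responds to substitution and that the ethyl group is not required for a lower number on this read-out. Going by these compounds alone, the only earlier step, a 2.3-fold lower number from compound 1 to compound 2 (0.36 log units; beyond the scatter) on the aromatic carbon, said nothing about this place; hydrogen now also lowers the number at a second, saturated site. No measurement at hand accounts for this change.

The compounds shown leave open whether a methyl group or a longer chain on this carbon would give a number nearer that of compound 1 or that of compound 3, and whether a hydroxyl group or an amine there would lower it further. They also leave open whether removing the ethyl group has the same effect on the core without the fluoro.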